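Compound 3 to Compound 4: an Ester Replaces an Ether

The source may hold more compounds than are shown below. What is called first, only, known or untested is meant among the compounds shown, and "the series" means these compounds.

Of the compounds shown here, three sharing one core have been tested in a functional assay on HeLa cells (Homo sapiens) for cytotoxicity, read by MTT assay; on this read-out lower numbers stand for stronger inhibition and higher numbers for weaker inhibition. Compound 1 `CC(C)=CC[C@@H](OC(=O)c1ccco1)C1=CC(=O)c2c(O)ccc(O)c2C1=O` carries a (furan-2-yl)carbonyl group on an oxygen on a saturated carbon and gives 80300 nM. Compound 2 `CC(C)=CC[C@@H](OC[C@@H](C)O)C1=CC(=O)c2c(O)ccc(O)c2C1=O` bears 2-hydroxypropyl on that oxygen instead and gives 22500 nM. Compound 3 `CC(=O)OCCO[C@H](CC=C(C)C)C1=CC(=O)c2c(O)ccc(O)c2C1=O` bears 2-acetoxyethyl there and gives 41500 nM. Compound 3 stands second highest of the three numbers, and both compound 2 and compound 1 lie within the scatter of it, so nothing separates those two from it. Within the data shown here, the only step beyond the scatter is a 3.6-fold lower number from compound 1 to compound 2 (0.55 log units; beyond the scatter).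

Compound 4 `CC[C@@](C)(O)CC(=O)O[C@H](CC=C(C)C)C1=CC(=O)c2c(O)ccc(O)c2C1=O` is the next to be measured. (2-hydroxy-2-methylbutyl)carbonyl in place of 2-acetoxyethyl on an oxygen on a saturated carbon The change brings back a carbonyl on that oxygen, as in compound 1, and adds a hydroxyl group, as in compound 2. The step of a 1.9-fold lower number from compound 1 to compound 3 (0.29 log units; within the scatter) and the step of a 1.8-fold higher number from compound 2 to compound 3 (0.27 log units; within the scatter) both stayed within the scatter, while a 3.6-fold lower number from compound 1 to compound 2 (0.55 log units; beyond the scatter) was modest. With these two features pointing in opposite directions, no move beyond the scatter is expected for compound 4 in this assay, and the expected step is a 1.1-fold higher number from compound 3 to compound 4 (0.04 log units; within the scatter). Compound 4 is therefore estimated at 45000 nM, with a range from 18000 nM to 110000 nM.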

Compound 4, half-maximal inhibitory concentration: 17900 nM
For compound 4 the middle estimate is 2.5-fold (0.40 log units) above the measured one; the whole stated range lies above it.
By their numbers in this assay, from the lowest: compounds 4, 2, 3 and 1 (each within the scatter of the next, the first and the last beyond it).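

In this assay the group on this oxygen can move the number beyond the scatter even when the starting point is compound 3: (2-hydroxy-2-methylbutyl)carbonyl in place of 2-acetoxyethyl gives a 2.3-fold lower number from compound 3 to compound 4 (0.37 log units; beyond the scatter). A carbonyl on that oxygen does not by itself fix the number, for compound 1 and compound 4 both carry one, and 2-hydroxy-2-methylbutyl in place of furan-2-yl on that carbonyl carbon gives a 4.5-fold lower number from compound 1 to compound 4 (0.65 log units; beyond the scatter). The ester of compound 4 and the ether of compound 2, each with a hydroxyl group in its chain, cannot be told apart, with a 1.3-fold lower number from compound 2 to compound 4 (0.10 log units; within the scatter), and no measurement offered here accounts for any of these steps.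

The part played by the hydroxyl group in compound 4 stays open, since no compound shown has the same chain without it, and the mirror-image form of its defined stereocentre is also absent from this set. Equally open, as far as these compounds go, is what an amine or a carboxylic acid in place of that hydroxyl group, or a longer chain on the carbonyl, would do to the number.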